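The compounds below may be only part of what the source reports. "The series", "measured", "known", "first", "only" and "open" are said of these compounds alone.

Compound 1 `O=C(Nc1ccc(-c2cscn2)cc1)C1CCCN(Cc2ccc(F)c(F)c2)C1`: 1240 nM
Compound 2 `O=C(Nc1ccc(-c2ccccn2)cc1)C1CCCN(Cc2ccc(F)c(F)c2)C1`: 11000 nM

In a functional assay on A-375 cells (Homo sapiens) for activation, with a stated time of 3 days (on this read-out higher numbers stand for an effect only at larger amounts of compound and lower numbers for an effect already at smaller amounts), compound 2, at 11000 nM, has the higher of the two measured numbers, and compound 1 stands nearest to it. Compound 3 `O=C(Nc1ccc(-c2ccoc2)cc1)C1CCCN(Cc2ccc(F)c(F)c2)C1` differs from compound 2 by one change, furan-3-yl in place of pyridin-2-yl on an aromatic carbon. Within the data shown here, only one measured step bears on this, an 8.9-fold higher number from compound 1 to compound 2 (0.95 log units; beyond the scatter), a modest step beyond the scatter, in which pyridin-2-yl replaced 1,3-thiazol-4-yl. Compound 3 gives up the same pyridin-2-yl, but for a different five-membered aromatic ring, so only part of that step is expected to be recovered in this assay. The expected change is a 4.4-fold lower number from compound 2 to compound 3 (0.64 log units; beyond the scatter), toward a lower number. For compound 3 the estimated value is 2500 nM, with an expected range of 800 nM to 8000 nM.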

Compound 3, half-maximal effective concentration: 3000 nM
Beside the measured number, compound 3's estimate is 1.2-fold (0.08 log units) below it; the range from low to high includes it.
By their numbers in this assay, from the lowest: compound 1; then compound 3; then compound 2.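

In this assay, furan-3-yl in place of pyridin-2-yl gives a 3.7-fold lower number from compound 2 to compound 3 (0.56 log units; beyond the scatter), so the move away from pyridin-2-yl at this carbon, para to a large group, lowers the number with a second five-membered aromatic ring and not only with 1,3-thiazol-4-yl. The two five-membered rings are still not equivalent: furan-3-yl in place of 1,3-thiazol-4-yl gives a 2.4-fold higher number from compound 1 to compound 3 (0.38 log units; beyond the scatter), and among these three compounds, none goes against the order of both five-membered rings lying below pyridin-2-yl. No measurement at hand explains either step.

The compounds shown leave open where a plain phenyl ring, furan-2-yl or a ring carrying an amine would fall at this position. They also leave open whether this order holds when the rest of the shared core changes.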